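The source may hold more compounds than are shown below. What is called first, only, known or untested is meant among the compounds shown, and "the series" means these compounds.

In a physicochemical assay, read by spectrophotometry, with a stated time of 10 min, tested at 0.05 mM, in the presence of a further agent that is not named here (a higher number here means a stronger effect of the compound at the concentration tested, a lower number a weaker effect), compound 2 `NCC(N)CCCNC(=O)CCn1cccc(O)c1=O` gives 24.8%. Compound 1 `NCC(N)CC(=O)N1CCN(C(=O)CCn2cccc(O)c2=O)CC1` gives 18.5% in this assay, a number lying within the usual scatter of that of compound 2, so the two cannot be ordered. Compound 3 `NCC(N)CCCCNC(=O)CCn1cccc(O)c1=O` has not been measured; it differs from compound 2 by 2,3-diaminopropyl in place of 1,2-diaminoethyl on a saturated chain carbon, three bonds along the chain from an amide-type nitrogen. Going by the values given here, no step between measured compounds is available to set a size for such a change, so only a small step is expected in this assay, in either direction or none beyond the scatter, estimated as a number 0.2 percentage points higher from compound 2 to compound 3 (within the scatter). Compound 3 is therefore expected to give 25%, within a range from 14% to 36%.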

Compound 3, a percentage reported as activity, at one concentration (the size of the read-out at that concentration, not a potency): 24.5%
Compound 3: the middle estimate sits 0.5 percentage points above what was measured; the range from low to high includes it.
By their numbers in this assay, from the lowest: compounds 1, 3 and 2 (each within the scatter of the next).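

In this assay, going by these compounds alone, the change to 2,3-diaminopropyl from 1,2-diaminoethyl on a saturated chain carbon, three bonds along the chain from an amide-type nitrogen, gives a number 0.3 percentage points lower from compound 2 to compound 3 (within the scatter) and so sets the first size for a change at this position. At this position, the read-out does not separate these two groups. No measurement shown bears on this result. Still open, as far as these compounds go, is whether 3,4-diaminobutyl at the same place would also stay within the scatter of compound 3, and what a carboxylic acid there would give.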